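A few compounds are considered here, and "the series" means these few. Any claim that something is new, unique, unknown or untested is made for them only; others in the source may bear on it.

Of the compounds shown here, three that share one core have been measured. Compound 1 `COc1cc(-c2nnc(SCC(=O)c3ccc(C)cc3)n2N)cc(OC)c1OC` gives 31300 nM in a functional assay on PC-3 cells (Homo sapiens) for antiproliferative activity, read by MTT assay, with a stated time of 48 h; on this read-out lower numbers stand for stronger inhibition and higher numbers for weaker inhibition. For compound 2 `COc1cc(-c2nnc(SCC(=O)c3ccc(F)cc3)n2N)cc(OC)c1OC` this assay reports only a limit, > 100000 nM (the limit of > 100000 nM in this assay, at which 1 of the 3 values shown sits). Compound 3 `COc1cc(-c2nnc(SCC(=O)c3ccccc3F)n2N)cc(OC)c1OC` gives 43100 nM in this assay and sits beside compound 1, since the step of a 1.4-fold higher number from compound 1 to compound 3 (0.14 log units; within the scatter) stays within the usual scatter, while an at least 2.3-fold lower number from compound 2 to compound 3 (0.36 log units; beyond the scatter) and an at least 3.1-fold higher number from compound 1 to compound 2 (0.50 log units; beyond the scatter) reach beyond it. Compound 4 `COc1cccc(NC(=O)CSc2nnc(-c3cc(OC)c(OC)c(OC)c3)n2N)c1` differs from compound 3 by (3-methoxyphenyl)amino in place of 2-fluorophenyl on a carbonyl carbon. Going by the values given here, none of the measured steps swaps an aryl ketone for an amide, so the expectation for compound 4 rests on compound 3 alone, with a step of a 1.2-fold higher number from compound 3 to compound 4 (0.06 log units; within the scatter) that is expected to stay within the scatter. Compound 4 is estimated at 50000 nM, between 15000 nM and 150000 nM.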

Compound 4, half-maximal inhibitory concentration: > 100000 nM
Compound 4: no number, only a limit; the forecaster's own chance of this, stated with the estimate: 30%; middle value at least 2.0-fold (0.30 log units) away from the limit.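

On the carbonyl carbon, (3-methoxyphenyl)amino gives weaker inhibition than the 2-fluorophenyl or 4-methylphenyl it replaces, with an at least 2.3-fold higher number from compound 3 to compound 4 (0.36 log units; beyond the scatter) and an at least 3.1-fold higher number from compound 1 to compound 4 (0.50 log units; beyond the scatter) in place of the earlier swaps of one aryl group for another. The step between compound 2 and compound 4 cannot be read, and compound 4 gives only a limit, not a number: the limit of > 100000 nM in this assay, at which 2 of the 4 values shown sit.

The compounds shown leave open whether this shift belongs to the amide link or to the methoxy group on its ring. Plain phenylamino or 4-methylphenylamino on the same carbonyl carbon would separate the two.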